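The source may report more compounds than this note shows. Statements on the series, on what has been measured and on what is new or still open speak of the compounds shown alone.

Compound 1 `CC(C)C(c1ccc(Cl)cc1)S(=O)(=O)Nc1nccs1`, compound 2 `CC(C)C(C(N)=O)c1ccc(Cl)cc1` and compound 3 `CC(C)[C@H](C(=O)NCc1ccccc1)c1ccc(Cl)cc1` were examined in a functional assay on CHO cells for agonist activity at Free fatty acid receptor 2 (Homo sapiens), read by cAMP accumulation; on this read-out lower numbers stand for stronger inhibition and higher numbers for weaker inhibition. In this assay compound 1 gives only a limit, > 100000 nM. Compound 2 likewise reaches no more than the limit, > 100000 nM. Compound 3 too gives only the limit, > 100000 nM. For the measured compounds named here, compound 3 thus stands where every value shown sits, at the limit of > 100000 nM in this assay, at which 3 of the 3 values shown sit, and no measured step offers a direction. Compound 4 `CC(C)[C@H](C(=O)Nc1cccnn1)c1ccc(Cl)cc1` differs from compound 3 by pyridazin-3-yl in place of benzyl on an amide-type nitrogen. With nothing measured to lean on, the expected step of a number no higher from compound 3 to compound 4 (the limit leaves the size open) is put at none beyond the scatter. Compound 4 is therefore estimated at 100000 nM, within a range from 5000 nM to 300000 nM, with a real chance that only a limit is reported again.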

Compound 4, half-maximal inhibitory concentration: 2300 nM
Beside the measured number, compound 4's estimate is 43-fold (1.64 log units) above it; measured number outside the range, below it.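

The change from benzyl to pyridazin-3-yl on an amide-type nitrogen brings an at least 43-fold lower number from compound 3 to compound 4 (1.63 log units; beyond the scatter), so in this assay this position can decide whether a number is obtained at all. Of the compounds shown, only compound 4 escapes the limit: the limit of > 100000 nM in this assay, at which 3 of the 4 values shown sit.

The change swaps a carbon-only ring for one with two ring nitrogens and also removes the benzyl carbon link, and the compounds shown cannot separate these two changes. As far as these compounds go, whether phenyl or pyridin-2-yl on the same nitrogen would keep the gain stays open.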